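Cytotoxicity limits in a stilbene series: compound 1 to compound 4

This account rests on a few compounds, and the source may have more. Where it says the series, first, only, none or still open, it means among the compounds named here.

Working notes on cytotoxicity in an ADME assay on BJ cells (Homo sapiens) for cytotoxicity, with a stated time of 72 h; on this read-out lower numbers stand for an effect already at smaller amounts and higher numbers for an effect only at larger amounts of compound. The series shares a core and varies the substituent on the aromatic ring. Compound 1 `C=C[C@@](C)(/C=C/c1ccc(OCc2ccccc2)cc1)CCC=C(C)C` carries a benzyloxy group; in this assay compound 1 gives only a limit of > 36600 nM, not a number. Compound 2 `C=C[C@@](C)(/C=C/c1ccc(O)cc1)CC/C=C(\C)CO` likewise reaches only the limit of > 36600 nM in this assay. Compound 3 `C=C[C@@](C)(/C=C/c1ccc(O)c(/C=C/C(=O)NCc2ccc(C(F)(F)F)cc2)c1)CCC=C(C)C` also sits at the limit of > 36600 nM in this assay. So far every value in this assay is a limit, (the limit of > 36600 nM in this assay, at which 3 of the 3 values shown sit), and compound 1 stands with the others at that same limit; no ordering among compounds 1, 2 and 3 can be read from these values.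

Compound 4 `C=C[C@@](C)(/C=C/c1ccc(-c2cccc(F)c2)cc1)CCC=C(C)C` differs from compound 1 by 3-fluorophenyl in place of benzyloxy on an aromatic carbon. Going by the values given here, no measured step between compounds in this assay is available, and the measured values give no direction for the change. With all three known values at the limit, the step that the limit leaves unreadable from compound 1 to compound 4 is expected to be none beyond the scatter, most likely ending again at a limit. Compound 4 is therefore estimated at 40000 nM, with a range from 15000 nM to 100000 nM.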

Compound 4, half-maximal effective concentration: > 36600 nM
Compound 4 gave a limit, no number; the forecaster's own chance of this, stated with the estimate: 80%; the middle value does not contradict the limit.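

Compound 4 gives only a limit in this assay, > 36600 nM, and the step from compound 1 to compound 4 cannot be read. The compounds shown leave open how they rank in this assay, and what 3-fluorophenyl in place of benzyloxy changes there: the limit of > 36600 nM in this assay, at which 4 of the 4 values shown sit.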